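Fluoro for trifluoromethyl in a weakly active series

A few compounds are considered here, and "the series" means these few. Any claim that something is new, unique, unknown or untested is made for them only; others in the source may bear on it.

For the measured compounds named here, in a functional assay on HT-29 cells (Homo sapiens) (a lower number here means a stronger inhibitor of growth, a higher number a weaker inhibitor of growth), compound 2 (`O=S(=O)(/C=C/c1ccc(C(F)(F)F)cc1F)Cc1ccc(Nc2ncnc3ccc(Br)cc23)cc1`) gives 100000 nM, the only true number so far. Compound 1 (`O=S(=O)(/C=C/c1ccc(Cl)cc1)Cc1ccc(Nc2ncnc3ccc(Br)cc23)cc1`) gives > 100000 nM, which is a limit of the assay and not a number. Going by the values given here, the single measured step, a number no higher from compound 1 to compound 2 (the limit leaves the size open), therefore offers no readable size to carry forward, and it concerns another change on the same aromatic ring.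

Compound 3 (`O=S(=O)(/C=C/c1ccc(F)cc1F)Cc1ccc(Nc2ncnc3ccc(Br)cc23)cc1`) carries fluoro in place of trifluoromethyl on an aromatic carbon, meta to a fluoro group and para to a large group (fluoro in place of trifluoromethyl on an aromatic carbon). The same difference reads 2-fluoro-4-(trifluoromethyl)phenyl to 2,4-difluorophenyl.

Among the compounds with values here, with no measured step of this kind, the expectation rests on compound 2 at 100000 nM. No step beyond the scatter is expected in this assay in either direction, and a second limit instead of a number is quite possible. The expected change is a 1.1-fold lower number from compound 2 to compound 3 (0.05 log units; within the scatter). For compound 3 the estimated value is 90000 nM, with an expected range of 30000 nM to 150000 nM.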

Compound 3, concentration for 50% growth inhibition: 100000 nM
For compound 3 the middle estimate is 1.1-fold (0.05 log units) below the measured one, within the range that was stated.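

Working notes on the position para to a large group: in this assay, fluoro in place of trifluoromethyl on an aromatic carbon gives no change at the digits printed from compound 2 to compound 3 (within the scatter). For the compounds shown here, this is the first step with a readable size, and it shows that, with the fluoro group meta to this position kept in place, the 2-fluoro-4-(trifluoromethyl)phenyl and 2,4-difluorophenyl compounds cannot be told apart in this assay. Steps from a limit cannot be read, and 2,4-difluorophenyl in place of 4-chlorophenyl gives a number no higher from compound 1 to compound 3 (the limit leaves the size open). Compound 1 gives a limit and not a number: the limit of > 100000 nM in this assay, at which 1 of the 3 values shown sits.

The compounds shown leave open whether any group on this aromatic carbon lowers the number in this assay, and an amine, a carboxylic acid or a methoxy group there would put that to the test. Also open, as far as these compounds go, is whether fluoro in place of trifluoromethyl stays within the scatter on a member of the series with a much lower number, where a step in either direction would have room to show.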